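From Ethyl to 4-Fluorophenyl on the Carbonyl Carbon

The source may report more compounds than this note shows. Statements on the series, on what has been measured and on what is new or still open speak of the compounds shown alone.

compound 1, `CCC(=O)N1CCN(Cc2nc3ccccc3n2Cc2cccc(C)c2)CC1`: 85.1%
compound 2, `CC(C)CCn1c(CN2CCN(C(=O)C3CC3)CC2)nc2ccccc21`: 70%

In an assay on isolated protein for inhibition of aldehyde dehydrogenase 1A1 (Homo sapiens), read by spectrophotometry, tested at 10 uM (a higher number here means more inhibition at the concentration tested (going by the name of the read-out), a lower number less inhibition), compound 1 gives 85.1%, the highest of the two numbers. Compound 2 gives 70%, a number lower by more than the usual scatter. Within the data shown here, compounds 1 and 2 differ in more than one place, so no single step between measured compounds is available.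

Compound 3, `Cc1cccc(Cn2c(CN3CCN(C(=O)c4ccc(F)cc4)CC3)nc3ccccc32)c1`, has not yet been measured in this assay. It differs from compound 1 in one place: 4-fluorophenyl in place of ethyl on a carbonyl carbon. Among the measured compounds shown here, nothing among the measured compounds shows what this exchange does, so the expectation rests on compound 1 alone. Compound 3 is expected to stay in the upper part of the range, with a step of a number 10.1 percentage points lower from compound 1 to compound 3 (beyond the scatter) expected to be small and downward, possibly not beyond the scatter. For compound 3 the estimate is 75%, with a range from 50% to 95%.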

Compound 3, a percentage reported as inhibition, at one concentration (the size of the read-out at that concentration, not a potency): 27.1%
Estimate against measurement, compound 3: 47.9 percentage points above, and the stated range ends above it.
By their numbers in this assay, from the lowest: compound 3; then compound 2; then compound 1.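

In this assay, among these compounds, the exchange of ethyl for 4-fluorophenyl on a carbonyl carbon comes out as a number 58 percentage points lower from compound 1 to compound 3 (beyond the scatter), the first single change that can be read. It shows that this place, on a carbonyl carbon whose other neighbour is an amide-type nitrogen in a ring, is far from indifferent to the group it carries: with the rest of compound 1 unchanged, this one exchange takes the read-out to the bottom of the three numbers. No measurement shown bears on what lies behind this drop.

The compounds shown leave open whether the loss goes with the aromatic ring or with the fluorine, a question that a plain phenyl at this place would separate. As far as these compounds go, how a longer chain such as butyl would fare there also remains open.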